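Compound 3 and the fluoro question

The source may report more compounds than this note shows. Statements on the series, on what has been measured and on what is new or still open speak of the compounds shown alone.

Values below come from a functional assay on MCF7 cells (Homo sapiens) for antiproliferative activity, read by MTT assay, with a stated time of 72 h (a higher number here means a weaker inhibitor, a lower number a stronger inhibitor), and nowhere else.
Compound 1 `COc1cc(-n2ncnc2-c2ccc(Cl)c(Cl)c2)cc(OC)c1OC` gives > 10000 nM (a limit)
Compound 2 `COc1cc(-n2ncnc2-c2cccc(Cl)c2)cc(OC)c1OC` gives > 10000 nM (a limit)
Compound 3 `COc1cc(-n2ncnc2-c2ccc(SC)cc2)cc(OC)c1OC` gives 390 nM (a number)

Among the measured compounds shown here, compound 3 holds the only true number here, and the rest of the set stands at the limit of > 10000 nM in this assay, at which 2 of the 3 values shown sit, for now. Between the two limits there is a step that the two limits leave unreadable from compound 1 to compound 2 to work with.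

Compound 4 `COc1cc(-n2ncnc2-c2ccc(F)cc2)cc(OC)c1OC` carries fluoro in place of methylsulfanyl on an aromatic carbon, para to a large group (fluoro in place of methylsulfanyl on an aromatic carbon). For the measured compounds named here, two measured steps bear on this change: an at least 25-fold lower number from compound 1 to compound 3 (1.40 log units; beyond the scatter) and also an at least 25-fold lower number from compound 2 to compound 3 (1.40 log units; beyond the scatter) (both large). Neither involves fluoro, so the read-across is loose. Reading an at least 25-fold lower number from compound 2 to compound 3 (1.40 log units; beyond the scatter) backwards, a large step to a higher number is expected in this assay for compound 4, and a limit is possible. The step this implies is an expected 7.7-fold higher number from compound 3 to compound 4 (0.89 log units; beyond the scatter) (an estimate). Compound 4 is estimated at 3000 nM (range 800 nM to 10000 nM).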

Compound 4, half-maximal inhibitory concentration: > 10000 nM
Compound 4 ended at the assay's limit; the forecaster's own chance of this, stated with the estimate: 35%; middle value at least 3.3-fold (0.52 log units) from the limit.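

In this assay, fluoro in place of methylsulfanyl on an aromatic carbon, para to a large group, gives an at least 25-fold higher number from compound 3 to compound 4 (1.40 log units; beyond the scatter). The steps from 3-chlorophenyl and 3,4-dichlorophenyl changed where the ring is substituted as well as the group, whereas here the place is fixed, so the change of group at that carbon alone separates a measured number from the limit. The value of compound 4 is a limit, not a number, and the steps to it from compound 1 and compound 2 cannot be read: the limit of > 10000 nM in this assay, at which 3 of the 4 values shown sit.

On these data alone, whether methoxy, an amine such as dimethylamino, or a longer chain such as ethylsulfanyl on this carbon would also give a number stays open. As far as these compounds go, the full size of the step also stays open, since the limit for compound 4 fixes only one end of it.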